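This account rests on a few compounds, and the source may have more. Where it says the series, first, only, none or still open, it means among the compounds named here.

Measured so far in an assay on isolated protein for inhibition of alkaline phosphatase, tissue-nonspecific isozyme (Homo sapiens); on this read-out higher numbers stand for weaker inhibition and lower numbers for stronger inhibition:
compound 1 `COc1ccc(S(=O)(=O)Nc2cccnc2)c(OC)c1` — 10300 nM
compound 2 `COc1cc(Cl)ccc1S(=O)(=O)Nc1cccnc1` — 4170 nM

For the measured compounds named here, only two compounds have numbers. Going by the values given here, the step of a 2.5-fold lower number from compound 1 to compound 2 (0.39 log units; beyond the scatter) is the single measured change. On the numbers shown, compound 2 gives the lowest value, and its nearest neighbour is compound 1, a modest distance away that lies beyond the scatter.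

Compound 3 `COc1cc(C)ccc1S(=O)(=O)Nc1cccnc1` is not yet measured. Its change from compound 2 is methyl in place of chloro on an aromatic carbon. Among the compounds with values here, no measured step covers a swap of chloro for methyl; the only step recorded, from compound 1 to compound 2, is a different exchange at the same carbon, so it bears on the present step only in showing that a change at this position of the core of compound 2 can shift this assay by a modest amount. On that thin basis, a step of no more than modest size is expected for compound 3, with no firm direction, though a slightly higher number than compound 2 is taken as the middle case: a 1.6-fold higher number from compound 2 to compound 3 (0.19 log units; within the scatter) is the expected step. Compound 3 is therefore estimated at 6500 nM, with a range from 2500 nM to 16000 nM.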

Compound 3, half-maximal inhibitory concentration: 896 nM
Estimate against measurement, compound 3: 7.3-fold (0.86 log units) above; measured number outside the range, below it.
By their numbers in this assay, from the lowest: compound 3; then compound 2; then compound 1.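

In this assay, the exchange of chloro for methyl gives a 4.7-fold lower number from compound 2 to compound 3 (0.67 log units; beyond the scatter), although each group counts one heavy atom, no hydrogen-bond donors or acceptors and no net charge, so these counts do not separate the two groups at this carbon, para to a large group and meta to a methoxy group. Measured against the methoxy compound, methyl at the same carbon gives an 11-fold lower number from compound 1 to compound 3 (1.06 log units; beyond the scatter), which places the three groups in the order methyl, chloro, methoxy from the lowest number to the highest, with compound 3 the most potent of the three, its steps to both others lying beyond the scatter. No evidence at hand bears on what lies behind this order.

The compounds shown leave open how an ethyl group, a bromine atom or an amine at this carbon would compare with methyl, and so whether the trend extends beyond these three groups. They also leave open whether the same order would hold if another part of the shared core were changed.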